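The source may report more compounds than this note shows. Statements on the series, on what has been measured and on what is new or still open speak of the compounds shown alone.

Working notes on the urea series tested in an assay on isolated protein for inhibition of proto-oncogene tyrosine-protein kinase receptor Ret (Homo sapiens), read by mobility shift assay, with a stated time of 1 h, tested at 10 uM; a lower number here means less inhibition, a higher number more inhibition at the concentration tested (going by the name of the read-out).

Of the compounds shown here, two have numbers so far. Compound 1 `CN(C)CCn1cnnc1-c1cc(Oc2ccc(NC(=O)Nc3ccc(F)c(F)c3)cc2F)ccn1` gives 17.6% in this assay. Compound 2 `CN(C)CCCn1cnnc1-c1cc(Oc2ccc(NC(=O)Nc3cccc(C(F)(F)F)c3)cc2F)ccn1` gives 85.6% in this assay and stands highest of the two numbers; the nearest value, that of compound 1, lies well beyond the scatter below it. Compounds 1 and 2 differ from each other in more than one place, so no single change can be read from that gap.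

Compound 3 `CN(C)CCCn1cnnc1-c1cc(Oc2ccc(NC(=O)Nc3ccc(F)c(F)c3)cc2F)ccn1` is the next member to be measured. It differs from compound 2 in one place: 3,4-difluorophenyl in place of 3-(trifluoromethyl)phenyl on an amide-type nitrogen. The group that enters is the same one that compound 1 carries on its amide-type nitrogen, while the chain on the triazole ring is that of compound 2. Compound 3 therefore sits between the two measured compounds in structure. For the measured compounds named here, the low reading of compound 1 17.6% suggests the step will go downwards and beyond the scatter, but with only two numbers its size is uncertain. Compound 3 is expected to come in around 45% in this assay, within 15% to 80%; the step from compound 2 is expected to be a number 40.6 percentage points lower from compound 2 to compound 3 (beyond the scatter).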

Compound 3, a percentage reported as inhibition, at one concentration (the size of the read-out at that concentration, not a potency): 30.9%
Estimate against measurement, compound 3: 14.1 percentage points above; the measured number falls inside the stated range.
By their numbers in this assay, from the lowest: compound 1; then compound 3; then compound 2.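

In this assay, with the rest of the structure held constant, 3,4-difluorophenyl in place of 3-(trifluoromethyl)phenyl on the amide-type nitrogen gives a number 54.7 percentage points lower from compound 2 to compound 3 (beyond the scatter), so the group at this position alone accounts for a large step. The chain can now also be read on its own: with 3,4-difluorophenyl held constant, (dimethylamino)methyl in place of dimethylamino on a saturated chain carbon, two bonds along the chain from an aromatic nitrogen, gives a number 13.3 percentage points higher from compound 1 to compound 3 (beyond the scatter), a step printed as modest, whereas the aryl step is printed as large. No measurement at hand bears on the origin of either step.

On these data alone, the chain step has been read only with 3,4-difluorophenyl on the amide-type nitrogen, so it remains open whether it carries over to 3-(trifluoromethyl)phenyl or continues with a longer chain. Also open, as far as these compounds go, is how this assay responds to other groups at this nitrogen, such as unsubstituted phenyl or 3-chlorophenyl, which would show whether the reading follows 3-(trifluoromethyl)phenyl specifically.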